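Swapping a hydroxypiperidine amide for a morpholine amide

The compounds below may be only part of what the source reports. "The series", "measured", "known", "first", "only" and "open" are said of these compounds alone.

Compound 1 `CCN(CC)S(=O)(=O)c1ccc(S(=O)(=O)N2CCC[C@@H](C(=O)N3CCC(O)CC3)C2)cc1` is the weakest of the three measured analogues: in a functional assay on MIA PaCa-2 cells (Homo sapiens) for inhibition, read by MTT assay, with a stated time of 7 days (on this read-out lower numbers stand for stronger inhibition and higher numbers for weaker inhibition), compound 1 gives 870 nM. Compound 2 `O=C([C@@H]1CCCN(S(=O)(=O)c2ccc(S(=O)(=O)C3CCC3)cc2)C1)N1CCC(F)(F)CC1` gives 9 nM in this assay, and compound 3 `CC(C)S(=O)(=O)c1ccc(S(=O)(=O)N2CCC[C@@H](C(=O)N3CCC(F)(F)CC3)C2)cc1` gives 11 nM, so compound 1 stands far above both. Among the measured compounds shown here, the only single-site step among them, a 1.2-fold higher number from compound 2 to compound 3 (0.09 log units; within the scatter), changes the group on a sulfonyl sulfur and leaves the amide untouched. Compound 4 `CCN(CC)S(=O)(=O)c1ccc(S(=O)(=O)N2CCC[C@@H](C(=O)N3CCOCC3)C2)cc1` differs from compound 1 by morpholin-4-yl in place of 4-hydroxypiperidin-1-yl on a carbonyl carbon. For the measured compounds named here, no measured step touches this amide position, and the counted difference is small, one ring atom and one hydrogen-bond donor. Compound 4 is therefore expected to stay near compound 1, with a step of a 1.4-fold higher number from compound 1 to compound 4 (0.14 log units; within the scatter) and an estimated 1200 nM, in a range from 300 nM to 4500 nM.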

Compound 4, half-maximal inhibitory concentration: 350 nM
Beside the measured number, compound 4's estimate is 3.4-fold (0.54 log units) above it; measured number inside the range.
By their numbers in this assay, from the lowest: compounds 2 and 3 (each within the scatter of the next); then compound 4; then compound 1.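

Among the compounds shown here, this is the first measured step at the amide position: in this assay the change gives a 2.5-fold lower number from compound 1 to compound 4 (0.40 log units; beyond the scatter), so the ring on this carbonyl carbon does affect the number, if only modestly. The shift is small, so this swap on the core of compound 1 does not bring a large gain in inhibition. No measurement shown here explains the shift. On these data alone, whether a piperazin-1-yl ring or an open-chain dimethylamino group on this carbonyl carbon would move the number further remains open. So does whether this swap would have the same effect with a different group on the other sulfonyl sulfur.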